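The source may report more compounds than this note shows. Statements on the series, on what has been measured and on what is new or still open speak of the compounds shown alone.

Measured compounds:
compound 1 `N#CC1(NC(=O)[C@@H]2C[C@@H](S(=O)(=O)c3ccccc3)CN2C(=O)c2ccccc2)CC1` — 29 nM
compound 2 `N#CC1(NC(=O)[C@@H]2C[C@@H](S(=O)(=O)c3ccccc3Cl)CN2C(=O)c2ccccc2)CC1` — 1 nM

In an assay on isolated protein for inhibition of cathepsin S (Mus musculus), read by fluorescence, with a stated time of 20 min (on this read-out higher numbers stand for weaker inhibition and lower numbers for stronger inhibition), compound 2 gives 1 nM, the lowest of the two numbers; compound 1 gives 29 nM. For the measured compounds named here, the only measured step is a 29-fold lower number from compound 1 to compound 2 (1.46 log units; beyond the scatter), a change on the aromatic ring of the sulfonyl group. Compound 3 `CC(=O)N1C[C@H](S(=O)(=O)c2ccccc2Cl)C[C@H]1C(=O)NC1(C#N)CC1` instead carries methyl in place of phenyl on a carbonyl carbon, that is benzoyl to acetyl. Going by the values given here, neither measured compound varies this carbonyl substituent, so the single measured step offers no guide here. The estimate is therefore held loose and leans toward a higher number, a 6.0-fold higher number from compound 2 to compound 3 (0.78 log units; beyond the scatter). Compound 3 is expected at 6 nM, with a range from 1 nM to 40 nM.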

Compound 3, half-maximal inhibitory concentration: 2 nM
Compound 3: the middle estimate sits 3.0-fold (0.48 log units) above what was measured; the range from low to high includes it.
By their numbers in this assay, from the lowest: compounds 2 and 3 (each within the scatter of the next); then compound 1.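

In this assay benzoyl and acetyl on the carbonyl carbon read alike (a 2.0-fold higher number from compound 2 to compound 3 (0.30 log units; within the scatter)). With the chloro group kept on the sulfonyl aromatic ring, the six-membered aromatic ring at this place is therefore not needed to stay in this range of numbers, and the much smaller methyl serves equally here. Nothing available accounts for this result.

Open, from the compounds shown here alone, is whether methyl and phenyl would still read alike on the compound without the chloro group. Also open, going by these compounds, is how a longer chain, an amine or a carboxylic acid would read on this carbonyl carbon.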